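The source may hold more compounds than are shown below. What is called first, only, known or untested is meant among the compounds shown, and "the series" means these compounds.

Compound 2 `CC1(C)[C@H]2CC[C@]1(C)N(Cc1cn(-c3ccc(F)cc3)nn1)C(=O)C2` carries a 4-fluorophenyl on the shared core, and in a functional assay on PANC-1 cells (Homo sapiens) for inhibition, read by MTT assay, with a stated time of 24 h (on this read-out lower numbers stand for stronger inhibition and higher numbers for weaker inhibition), compound 2 gives 110 nM. Among the three measured numbers this is the second highest. Compound 3 `CC1(C)[C@H]2CC[C@]1(C)N(Cc1cn(-c3ccc(O)cc3)nn1)C(=O)C2` gives 100 nM, so there is a 1.1-fold lower number from compound 2 to compound 3 (0.04 log units; within the scatter). Compound 1 `COc1ccc(-n2cc(CN3C(=O)C[C@@H]4CC[C@@]3(C)C4(C)C)nn2)cc1` gives 330 nM, and there is a 3.0-fold lower number from compound 1 to compound 2 (0.48 log units; beyond the scatter) as well as a 3.3-fold lower number from compound 1 to compound 3 (0.52 log units; beyond the scatter). Compound 4 `Cc1cccc(-n2cc(CN3C(=O)C[C@@H]4CC[C@@]3(C)C4(C)C)nn2)c1` brings a different change: 3-methylphenyl in place of 4-fluorophenyl on an aromatic nitrogen. The measured steps only swap groups on the same aromatic carbon, and none of them involves a methyl or a 3-methylphenyl, so they give weak guidance; the two modest steps suggest at most a modest shift in either direction. The expected step is a 1.5-fold higher number from compound 2 to compound 4 (0.16 log units; within the scatter). Compound 4 is therefore estimated at 160 nM, with a range from 60 nM to 420 nM.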

Compound 4, half-maximal inhibitory concentration: 240 nM
Beside the measured number, compound 4's estimate is 1.5-fold (0.18 log units) below it; the measured number falls inside the stated range.
By their numbers in this assay, from the lowest: compounds 3 and 2 (each within the scatter of the next); then compounds 4 and 1 (each within the scatter of the next).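

Placing 3-methylphenyl on the aromatic nitrogen gives a step beyond the scatter when it replaces 4-fluorophenyl (a 2.2-fold higher number from compound 2 to compound 4 (0.34 log units; beyond the scatter)) or 4-hydroxyphenyl (a 2.4-fold higher number from compound 3 to compound 4 (0.38 log units; beyond the scatter)). When it replaces 4-methoxyphenyl, the step stays within the scatter (a 1.4-fold lower number from compound 1 to compound 4 (0.14 log units; within the scatter)), so the same incoming group reads differently depending on which group leaves. Nothing available explains these steps.

The compounds shown cannot separate the identity of the group from its place on the ring, which a 4-methylphenyl or 3-fluorophenyl would help to do. On these data alone, how an aminophenyl would read also remains open.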